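This account rests on a few compounds, and the source may have more. Where it says the series, first, only, none or still open, it means among the compounds named here.

Compound 1 `C/C(=N\O)c1ccc(NC(=O)Cn2nc(-c3ccc(Cl)cc3)nc2N)cc1` and compound 2 `c1ccc(-c2nc3sc(-c4ccccc4)cn3n2)cc1` have been tested in a functional assay on NCI-H522 cells (Homo sapiens) for inhibition, read by sulforhodamine B assay, with a stated time of 48 h, tested at 10 uM; on this read-out higher numbers stand for more inhibition of growth at the one concentration tested and lower numbers for less inhibition of growth. Compound 1 gives 31.5%, the higher of the two numbers, while compound 2 gives 19%, a gap beyond the usual scatter. Compound 3 `CC(=O)c1ccc(NC(=O)Cn2nc(-c3ccc(Cl)cc3)nc2N)cc1` differs from compound 1 in one place: a group of 3 heavy atoms (2 carbon, 1 oxygen; no ring) in place of a group of 4 heavy atoms (2 carbon, 1 nitrogen, 1 oxygen; no ring), on an aromatic carbon. Within the data shown here, no step between measured compounds of this kind is known, so the change can only be judged from the structures. The expected step is small, a number 2.5 percentage points lower from compound 1 to compound 3 (within the scatter), not beyond the scatter in either direction. Compound 3 is therefore expected to give about 29%, between 14% and 44%.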

Compound 3, percent growth inhibition at one concentration: 28%
Compound 3: middle estimate off by 1 percentage points, on the high side; measured number inside the range.
By their numbers in this assay, from the lowest: compounds 2, 3 and 1 (each within the scatter of the next, the first and the last beyond it).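

In this assay, putting acetyl on the aromatic carbon para to a large group gives a number 3.5 percentage points lower from compound 1 to compound 3 (within the scatter), so this change does not separate the two compounds. Acetyl carries 0 hydrogen-bond donors against 1 in the group it replaces, yet the step stays inside the scatter. No measurement at hand explains this result. As far as these compounds go, whether an amine or a carboxylic acid on this carbon would read the same stays open. So does whether compound 1 and compound 3 would remain level at other concentrations.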